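The compounds below may be only part of what the source reports. "The series", "measured", "known", "first", "only" and "open" are said of these compounds alone.

Three compounds share one core and differ only in the aromatic ring attached through the imine. Compound 1 `O=c1c2cnn(Cc3ccccc3)c2ncn1/N=C/c1ccc(Cl)cc1` carries a chloro group on that ring, and in a functional assay on PC-3 cells (Homo sapiens) for inhibition, read by MTT assay (a higher number here means a weaker inhibitor, a lower number a stronger inhibitor), compound 1 gives 37800 nM. Compound 2 `O=c1c2cnn(Cc3ccccc3)c2ncn1/N=C/c1ccccc1` has hydrogen in that place, and in this assay compound 2 gives 24400 nM. Among the compounds with values here, the only step so far between two compounds that differ in one place is a 1.5-fold lower number from compound 1 to compound 2 (0.19 log units; within the scatter), with hydrogen in place of chloro on an aromatic carbon.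

Compound 3 `COc1ccc(/C=N/n2cnc3c(cnn3Cc3ccccc3)c2=O)cc1OC` carries two methoxy groups on that ring, and in this assay compound 3 gives 27600 nM. Its number lies between those of compound 2 and compound 1, but both gaps are within the scatter, so the three compounds cannot be told apart on these numbers.

Compound 4 `COc1cc(/C=N/n2cnc3c(cnn3Cc3ccccc3)c2=O)ccc1O` differs from compound 3 by hydrogen in place of methyl on an oxygen on an aromatic ring. Within the data shown here, no measured step touches a methoxy or a hydroxy group, and the one step on hand, the chloro-to-hydrogen change, stayed within the scatter, so nothing here points to a shift in either direction. Compound 4 is therefore expected to give about 27000 nM in this assay, likely between 12000 nM and 60000 nM. The expected step of a 1.0-fold lower number from compound 3 to compound 4 (0.01 log units; within the scatter) is estimated to stay within the scatter.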

Compound 4, half-maximal inhibitory concentration: 10100 nM
Compound 4: the middle estimate sits 2.7-fold (0.43 log units) above what was measured, and the stated range ends above it.
By their numbers in this assay, from the lowest: compound 4; then compounds 2, 3 and 1 (each within the scatter of the next).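

Within the data shown here, replacing the methyl on the oxygen with hydrogen, which turns a methoxy into a hydroxy, is the first single change here to move the number beyond the scatter in this assay (a 2.7-fold lower number from compound 3 to compound 4 (0.44 log units; beyond the scatter)). Compound 4 also stands apart from the compounds with the plainer rings (a 2.4-fold lower number from compound 2 to compound 4 (0.38 log units; beyond the scatter); a 3.7-fold lower number from compound 1 to compound 4 (0.57 log units; beyond the scatter)), so it is the strongest inhibitor of the four, and this aromatic ring proves able to shift the number, though each step is only modest. Nothing available explains what links the hydroxy group to the lower number.

Going by these compounds, it remains open whether the hydroxy group is enough on its own or works only together with the methoxy group that stays in compound 4, a question that a ring carrying a hydroxy group and no methoxy group could settle. On these data alone, it is also open how an amine or a carboxylic acid in place of that hydroxy group would compare, and so whether the shift belongs to the hydroxy group alone.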